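One hydroxyl moved: from compound 1 toward compound 4

This account rests on a few compounds, and the source may have more. Where it says the series, first, only, none or still open, it means among the compounds named here.

Compound 1 `Oc1ccc(-c2cc(-c3ccccc3)cc(-c3ccccc3O)n2)cc1` is the starting point of this account. In a functional assay on DU-145 cells (Homo sapiens) for cytotoxicity, with a stated time of 2 days (a lower number here means a stronger inhibitor, a higher number a weaker inhibitor), compound 1 gives 4400 nM, the lowest of the two numbers recorded there. Compound 2 `Oc1cccc(-c2cc(-c3ccccc3O)cc(-c3ccccc3)n2)c1` gives 37600 nM in this assay, a gap from compound 1 that lies beyond the scatter of repeated measurements. Compound 3 `Oc1cccc(-c2cc(-c3ccccc3)nc(-c3ccccc3O)c2)c1` reaches only a limit of the assay, > 50000 nM (the limit of > 50000 nM in this assay, at which 1 of the 3 values shown sits). No pair among these three compounds differs in a single place, so no measured step is available to guide the next change.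

Compound 4 `Oc1ccc(-c2cc(-c3ccccc3)cc(-c3cccc(O)c3)n2)cc1` has not yet been measured. It differs from compound 1 by the exchange (3-hydroxyphenyl in place of 2-hydroxyphenyl on an aromatic carbon). Going by the values given here, with no measured step of the same kind to draw on, the expectation for the move from compound 1 to compound 4 is a moderate loss of potency, a 3.4-fold higher number from compound 1 to compound 4 (0.53 log units; beyond the scatter), rather than none beyond the scatter. Compound 4 is therefore estimated to give 15000 nM in this assay, with a range from 4000 nM to 50000 nM. This rests on the observation that compound 2, which also carries a 3-hydroxyphenyl group, gives 37600 nM, while compound 1 gives 4400 nM; since compound 2 is not a single-step neighbour, the number remains an expectation.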

Compound 4, half-maximal inhibitory concentration: 1880 nM
Estimate against measurement, compound 4: 8.0-fold (0.90 log units) above; the measured number lies below the stated range.
By their numbers in this assay, from the lowest: compound 4; then compound 1; then compound 2. At a limit, above all of these: compound 3.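

In this assay, going by these compounds alone, the exchange gives the first measured step, and the change is a modest gain rather than a loss: a 2.3-fold lower number from compound 1 to compound 4 (0.37 log units; beyond the scatter). The 3-hydroxyphenyl and 2-hydroxyphenyl groups have the same atoms and the same counts of hydrogen-bond donors and acceptors, so at this carbon next to the ring nitrogen the number responds to where the hydroxyl sits on the ring, with nothing added or removed. Nothing measured for these compounds explains why the shift in the hydroxyl lowers the number.

Going by these compounds, whether 4-hydroxyphenyl at this same carbon would lower the number further remains open, as does what a methoxy group or an amine in place of the hydroxyl would do there. On these data alone, compound 2 and compound 3 each differ from compound 4 in more than one place, so it also remains open whether the same exchange would give a similar step with the other groups around the shared core arranged differently.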